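A few compounds are considered here, and "the series" means these few. Any claim that something is new, unique, unknown or untested is made for them only; others in the source may bear on it.

Measured compounds:
compound 1, `Cn1cccc1-c1cc(-c2ccc(Br)cc2)[nH]c(=O)c1C#N`: 47300 nM
compound 2, `COc1ccc(-c2cc(-c3cccn3C)c(C#N)c(=O)[nH]2)cc1OC`: 5010 nM
compound 3, `COc1ccc(-c2cc(-c3cccs3)[nH]c(=O)c2C#N)cc1`: 23400 nM

These three compounds share a core and were tested in a functional assay on CCRF-CEM cells (Homo sapiens) for cytotoxicity, read by sulforhodamine B assay, with a stated time of 48 h; a lower number here means a stronger inhibitor of growth, a higher number a weaker inhibitor of growth. Compound 1 gives the highest number of the three: compound 3 sits nearest to it, and compound 2 furthest, both with lower numbers. Compound 4, `Cn1cccc1-c1cc(-c2ccc(Br)cc2)n(C(=S)Nc2ccc(F)cc2)c(=O)c1C#N`, has not yet been measured. It differs from compound 1 by a group of 10 heavy atoms (7 carbon, 1 nitrogen, 1 fluorine, 1 sulfur; one six-membered aromatic ring of carbon only) in place of a hydrogen atom, on an aromatic nitrogen. Within the data shown here, no measured pair shows this kind of change, so the direction is uncertain; a modest step toward a lower number is expected, a 2.4-fold lower number from compound 1 to compound 4 (0.37 log units; beyond the scatter), with wide uncertainty. Compound 4 is therefore estimated at 20000 nM, in the range 4000 nM to 100000 nM.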

Compound 4, concentration for 50% growth inhibition: > 100000 nM
Compound 4 was reported as a limit (the forecaster's own chance of this, stated with the estimate: 15%); middle value at least 5.0-fold (0.69 log units) from the limit.
By their numbers in this assay, from the lowest: compound 2; then compound 3; then compound 1. At a limit, above all of these: compound 4.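

In this assay, replacing the hydrogen atom on the aromatic nitrogen with the group of 10 heavy atoms gives an at least 2.1-fold higher number from compound 1 to compound 4 (0.32 log units; beyond the scatter), which shows that growth inhibition responds to a change at this position and that this change weakens it. Compound 4 stands only as a limit of the assay, so the full size of the loss remains unknown: the limit of > 100000 nM in this assay, at which 1 of the 4 values shown sits.

On these data alone, whether a small methyl or acetyl group on this nitrogen would keep the growth inhibition of compound 1 remains open. The compounds shown also cannot tell which part of the entering group, the sulfur-bearing link or the fluorine-bearing aromatic ring, matters for the change.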